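The source may hold more compounds than are shown below. What is called first, only, known or untested is meant among the compounds shown, and "the series" means these compounds.

Three compounds have been measured in a functional assay on HeLa cells (Homo sapiens) for cytotoxicity, read by MTT assay; on this read-out higher numbers stand for weaker inhibition and lower numbers for stronger inhibition:
compound 1 `CC(=O)OCCC(=O)O[C@H](CC=C(C)C)C1=CC(=O)c2c(O)ccc(O)c2C1=O` gives 17300 nM
compound 2 `CC[C@](C)(O)CC(=O)O[C@H](CC=C(C)C)C1=CC(=O)c2c(O)ccc(O)c2C1=O` gives 30200 nM
compound 3 `CC(C)=CC[C@@H](OCC(C)O)C1=CC(=O)c2c(O)ccc(O)c2C1=O` gives 24700 nM

Compound 3 stands second highest of these three numbers; its nearest value is that of compound 2 and its furthest that of compound 1, and the steps of a 1.2-fold lower number from compound 2 to compound 3 (0.09 log units; within the scatter) and a 1.4-fold higher number from compound 1 to compound 3 (0.15 log units; within the scatter) both lie within the scatter. Compound 4 `CCCCC(C)(O)CC(=O)O[C@H](CC=C(C)C)C1=CC(=O)c2c(O)ccc(O)c2C1=O` has not yet been measured. It differs from compound 3 in one place: (2-hydroxy-2-methylhexyl)carbonyl in place of 2-hydroxypropyl on an oxygen on a saturated carbon. Among the measured compounds shown here, the step from compound 2 to compound 3, which replaced a (2-hydroxy-2-methylbutyl)carbonyl group with 2-hydroxypropyl, is the closest precedent and was small, as was the step from compound 1. A step of a 1.1-fold higher number from compound 3 to compound 4 (0.05 log units; within the scatter) is therefore expected, with no clear direction beyond the scatter. The estimate for compound 4 in this assay is 28000 nM, within 12000 nM to 70000 nM.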

Compound 4, half-maximal inhibitory concentration: 60600 nM
Beside the measured number, compound 4's estimate is 2.2-fold (0.34 log units) below it, and the stated range covers the measured number.
By their numbers in this assay, from the lowest: compounds 1, 3, 2 and 4 (each within the scatter of the next, the first and the last beyond it).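

In this assay, among the compounds shown here, (2-hydroxy-2-methylhexyl)carbonyl on this oxygen on a saturated carbon gives the first steps beyond the scatter, both modest (a 2.5-fold higher number from compound 3 to compound 4 (0.39 log units; beyond the scatter); a 3.5-fold higher number from compound 1 to compound 4 (0.54 log units; beyond the scatter)). Set against the 2-hydroxy-2-methylbutyl version, however, the change from 1-hydroxy-1-methylpropyl to 1-hydroxy-1-methylpentyl stays within the scatter (a 2.0-fold higher number from compound 2 to compound 4 (0.30 log units; within the scatter)), so chain length alone is not shown to matter here.

On these data alone, whether an amine, a carboxylic acid or a still longer chain at this place would move the number further remains open. Nothing available accounts for the steps seen.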